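This account rests on a few compounds, and the source may have more. Where it says the series, first, only, none or still open, it means among the compounds named here.

- Compound 1 `CCCCCCCCCCCC[C@@H](O)[C@H]1CC[C@H]([C@H](O)CCCCCCCCCCNC(=O)c2ccnn2C)O1`: 10 nM
- Compound 2 `CCCCCCCCCCCC[C@@H](O)[C@H]1CC[C@H]([C@H](O)CCCCCCCCCCNCc2ccnn2C)O1`: 309 nM

In a functional assay on MKN-7 cells (Homo sapiens) for inhibition, read by sulforhodamine B assay, with a stated time of 48 h (a lower number here means a stronger inhibitor of growth, a higher number a weaker inhibitor of growth), compound 2 has the higher number of the two, at 309 nM. Compound 3 `CCCCCCCCCCCC[C@@H](O)[C@H]1CC[C@H]([C@H](O)CCCCCCCCCCC(=O)Nc2ccnn2C)O1` has not yet been measured. It differs from compound 2 as follows: (1-methyl-1H-pyrazol-5-yl)carbamoyl in place of ((1-methyl-1H-pyrazol-5-yl)methyl)amino on a saturated chain carbon, ten or more bonds along the chain from an oxygen on a saturated carbon and a saturated ring carbon. Going by the values given here, the one measured step that bears on this is a 31-fold higher number from compound 1 to compound 2 (1.49 log units; beyond the scatter), a large change that removed a carbonyl. Compound 3 has a carbonyl again, but within a carbamoyl group, which compound 1 does not carry, so only part of that step is expected to be recovered. A sizeable drop is expected in this assay, a 7.7-fold lower number from compound 2 to compound 3 (0.89 log units; beyond the scatter). For compound 3 the estimated value is 40 nM, within an expected range of 10 nM to 160 nM.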

Compound 3, concentration for 50% growth inhibition: 20900 nM
Compound 3: the middle estimate sits 520-fold (2.72 log units) below what was measured; measured number outside the range, above it.
By their numbers in this assay, from the lowest: compound 1; then compound 2; then compound 3.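

In this assay, a carbonyl in the linker does not by itself preserve growth inhibition: replacing ((1-methyl-1H-pyrazol-5-yl)carbonyl)amino with (1-methyl-1H-pyrazol-5-yl)carbamoyl, which reverses the amide, gives a 2100-fold higher number from compound 1 to compound 3 (3.32 log units; beyond the scatter). The carbamoyl linker also falls behind the carbonyl-free ((1-methyl-1H-pyrazol-5-yl)methyl)amino linker, with a 68-fold higher number from compound 2 to compound 3 (1.83 log units; beyond the scatter). Nothing available explains this loss. From the compounds shown here alone, it remains open how a urea or a sulfonamide linking the same 1-methyl-1H-pyrazol-5-yl ring would compare, and whether the carbamoyl penalty would persist with a longer chain.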